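Aryl hydrazone variation on the shared core, cytotoxicity

The compounds below may be only part of what the source reports. "The series", "measured", "known", "first", "only" and "open" are said of these compounds alone.

The three measured compounds share the core of compound 1, `CN(C)CCn1cnnc1-c1cc(Oc2ccc(NC(=O)N/N=C/c3ccc(Cl)cc3)cc2F)ccn1`, and differ only in the aryl group on a carbon with a double bond to nitrogen. In a functional assay on A549 cells (Homo sapiens) for cytotoxicity, read by MTT assay, with a stated time of 72 h (a lower number here means a stronger inhibitor, a higher number a weaker inhibitor), compound 1 gives 780 nM, the lowest of the two numbers shown. Compound 3, `CN(C)CCn1cnnc1-c1cc(Oc2ccc(NC(=O)N/N=C/c3c(O)ccc4ccccc34)cc2F)ccn1`, gives 880 nM in this assay, and the step of a 1.1-fold higher number from compound 1 to compound 3 (0.05 log units; within the scatter) lies within the scatter. Compound 2, `CN(C)CCn1cnnc1-c1cc(Oc2ccc(NC(=O)N/N=C/c3cc(Br)c(O)c(Br)c3)cc2F)ccn1`, reaches only a limit of this assay, > 100000 nM, so that an at least 120-fold higher number from compound 1 to compound 2 (2.10 log units; beyond the scatter) and an at least 110-fold lower number from compound 2 to compound 3 (2.05 log units; beyond the scatter) are both large, with the limit of > 100000 nM in this assay, at which 1 of the 3 values shown sits, marking the boundary.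

Compound 4, `COc1ccc(/C=N/NC(=O)Nc2ccc(Oc3ccnc(-c4nncn4CCN(C)C)c3)c(F)c2)cc1O`, differs from compound 1 as follows: 3-hydroxy-4-methoxyphenyl in place of 4-chlorophenyl on a carbon with a double bond to nitrogen. Two of the measured steps bear on this change: one hydroxylated aryl (compound 3) left the number unchanged, the other (compound 2) removed all measurable activity. The group entering in compound 4 shares features of each, so a weakening step of uncertain size is expected, a 3.8-fold higher number from compound 1 to compound 4 (0.59 log units; beyond the scatter). The expected value for compound 4 is 3000 nM, within 600 nM to 40000 nM.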

Compound 4, half-maximal inhibitory concentration: > 100000 nM
Compound 4: no number, only a limit (the forecaster's own chance of this, stated with the estimate: 20%); middle value at least 33-fold (1.52 log units) from the limit.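

In this assay compound 4 gives no number, only a limit: the limit of > 100000 nM in this assay, at which 2 of the 4 values shown sit.

The loss of activity on this carbon therefore does not depend on bromine, since 3-hydroxy-4-methoxyphenyl in place of 4-chlorophenyl gives an at least 120-fold higher number from compound 1 to compound 4 (2.10 log units; beyond the scatter), and the step to the hydroxylated naphthalene gives an at least 110-fold higher number from compound 3 to compound 4 (2.05 log units; beyond the scatter). The step from compound 2 to compound 4 cannot be read, and compound 3 goes against any rule that a hydroxyl on the aryl group alone ends activity.

The compounds shown leave open whether the hydroxyl or the methoxy of compound 4 goes with the loss, as a phenyl carrying only a methoxy group or only a hydroxyl group would separate the two. Also open, from the compounds shown here alone, is how an amino group on the phenyl ring would behave at this place.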